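Compound 4 expected from compound 2

The source may report more compounds than this note shows. Statements on the series, on what has been measured and on what is new or still open speak of the compounds shown alone.

Compound 1 is `Cc1ccc2c(NCc3ccc(NC(=O)C4CCN(Cc5ccccc5)CC4)cc3)nc(N3CCC(N4CCCC4)CC3)nc2c1`; in a functional assay on SV5A8 cells (Homo sapiens) for cytotoxicity (on this read-out lower numbers stand for stronger inhibition and higher numbers for weaker inhibition), compound 1 gives only a limit, > 8090 nM.
Compound 2 is `Cc1ccc2c(NCc3ccc(NC(=O)C4CCN(Cc5ncc[nH]5)CC4)cc3)nc(N(C)C)nc2c1`; in this assay compound 2 gives only a limit, > 20000 nM.
Compound 3 is `Cc1ccc2c(NCc3ccc(NC(=O)C4CCN(Cc5ccccc5)CC4)cc3)nc(N(C)CCCN(C)C)nc2c1`; in this assay compound 3 gives only a limit, > 8620 nM.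

None of the three measured compounds has a number in this assay; each stands at a limit of the assay. Compound 2 stands at the limit of > 20000 nM in this assay, at which 1 of the 3 values shown sits. Compound 1 stands at the limit of > 8090 nM in this assay, at which 1 of the 3 values shown sits. Compound 3 stands at the limit of > 8620 nM in this assay, at which 1 of the 3 values shown sits. Within the data shown here, the one step with both ends measured, a step that the two limits leave unreadable from compound 1 to compound 3, cannot be read because both ends are limits, and it concerns a different position of the shared core.

Compound 4 is `COc1ccc(CN2CCC(C(=O)Nc3ccc(CNc4nc(N(C)C)nc5cc(C)ccc45)cc3)CC2)cc1`. It differs from compound 2 by 4-methoxyphenyl in place of 1H-imidazol-2-yl on a saturated chain carbon bound to an amine nitrogen in a ring. Among the measured compounds shown here, no measured step touches the group on the saturated chain carbon bound to the amine nitrogen in a ring, so the data give no size for this change in either direction.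

With nothing to point away from the limit, compound 4 is expected to remain at the limit as well, the step of a number no higher from compound 2 to compound 4 (the limit leaves the size open) being estimated as none beyond the scatter. The estimate for compound 4 in this assay is 20000 nM, with a range from 6000 nM to 60000 nM.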

Compound 4, half-maximal inhibitory concentration: > 6180 nM
Compound 4 gave a limit, no number; the forecaster's own chance of this, stated with the estimate: 80%; the middle value does not contradict the limit.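

In this assay compound 4 gives only a limit, > 6180 nM. Compound 2 likewise gives only a limit, > 20000 nM, so the step between compound 2 and compound 4 cannot be read. The compounds shown leave open whether 4-methoxyphenyl in place of 1H-imidazol-2-yl changes the result in this assay at all; none of the four has a number there.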